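Dropping the Methyl from the Ring Nitrogen

A few compounds are considered here, and "the series" means these few. Any claim that something is new, unique, unknown or untested is made for them only; others in the source may bear on it.

Compound 1 `Cn1ccc2cc(-c3ccn4c(CC(F)(F)F)cnc4c3C#N)ccc21`: 154% in a functional assay on CHO cells for agonist activity at metabotropic glutamate receptor 2 (Homo sapiens); a lower number here means a smaller maximal response, a higher number a larger maximal response
Compound 2 `N#Cc1c(-c2ccc(OC3CCOCC3)c(Cl)c2)ccn2c(CC(F)(F)F)cnc12`: 173%
Compound 3 `Cn1ccc2cc(-c3ccn4c(CC(F)(F)F)cnc4c3C#N)cc(Cl)c21`: 184%

Compound 3 stands highest of these three numbers in this assay; compound 2 is nearest and compound 1 furthest, both beyond the scatter. Among the compounds with values here, the only measured step that touches compound 3 is a number 30 percentage points higher from compound 1 to compound 3 (beyond the scatter), which comes from chloro in place of hydrogen on an aromatic carbon.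

Compound 4 `N#Cc1c(-c2cc(Cl)c3[nH]ccc3c2)ccn2c(CC(F)(F)F)cnc12` differs from compound 3 by hydrogen in place of methyl on an aromatic nitrogen. Within the data shown here, no measured pair swaps hydrogen for methyl on an aromatic nitrogen, so no measured step bears directly on this change, and the chloro step gives no guidance on it. The step of a number 9 percentage points lower from compound 3 to compound 4 (within the scatter) is therefore expected to stay within the scatter. Compound 4 is estimated at 175%, with a range from 150% to 200%.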

Compound 4, largest response reached (Emax), in percent of the reference or control that the assay uses: 277%
Estimate against measurement, compound 4: 102 percentage points below; the measured number lies above the stated range.
By their numbers in this assay, from the lowest: compound 1; then compound 2; then compound 3; then compound 4.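

On the aromatic nitrogen of the five-membered ring, the loss of one heavy atom, a methyl, gives a number 93 percentage points higher from compound 3 to compound 4 (beyond the scatter) in this assay. This large step shows that the response is highly sensitive to this nitrogen's substituent, and it exceeds the modest chloro step, a number 30 percentage points higher from compound 1 to compound 3 (beyond the scatter) on the same part of the molecule. No measurement available here explains why this change has such a large effect.

From the compounds shown here alone, it remains open whether the same change would give a comparable step without the chloro group. Going by these compounds, how an ethyl group or a longer chain on this nitrogen would compare also remains unknown.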